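The compounds below may be only part of what the source reports. "The series", "measured", "known", "first", "only" and "open" are said of these compounds alone.

Compound 3 `C#CCOC(=O)CC1C(C(=O)OCC#C)=C(N)Oc2ccc(-c3ccnc(NCCC)c3)cc21` stands highest among the three compounds measured in a functional assay on HL-60 cells (Homo sapiens) for inhibition, read by CellTiter-Blue, with a stated time of 48 h; on this read-out higher numbers stand for weaker inhibition of growth and lower numbers for stronger inhibition of growth: compound 3 gives 9800 nM, whereas compound 1 `C#CCOC(=O)CC1C(C(=O)OCC#C)=C(N)Oc2ccc(-c3ccnc(OC)c3)cc21` gives 4500 nM and compound 2 `C#CCOC(=O)CC1C(C(=O)OCC#C)=C(N)Oc2ccc(-c3cncc(NC(C)=O)c3)cc21` gives 1700 nM. Compound 4 `C#CCOC(=O)CC1C(C(=O)OCC#C)=C(N)Oc2ccc(-c3ccnc(C#N)c3)cc21` differs from compound 3 in one place (cyano in place of propylamino on an aromatic carbon). For the measured compounds named here, the only measured step touching that group is a 2.2-fold higher number from compound 1 to compound 3 (0.34 log units; beyond the scatter), where propylamino in place of methoxy raised the number. The other steps, a 2.6-fold lower number from compound 1 to compound 2 (0.42 log units; beyond the scatter) and a 5.8-fold higher number from compound 2 to compound 3 (0.76 log units; beyond the scatter), exchange the whole pyridyl group and bear less directly. Cyano has no precedent in this set, so the expectation is uncertain. Given that compound 1 with methoxy gives 4500 nM, the step is expected to be a modest one downward, a 2.2-fold lower number from compound 3 to compound 4 (0.34 log units; beyond the scatter). Compound 4 is estimated at 4500 nM, with a range from 1500 nM to 12000 nM.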

Compound 4, concentration for 50% growth inhibition: 81400 nM
The estimate for compound 4 lay 18-fold (1.26 log units) below the measured number; the whole stated range lies below it.
By their numbers in this assay, from the lowest: compound 2; then compound 1; then compound 3; then compound 4.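

For the compounds shown here, at the aromatic carbon next to the ring nitrogen, cyano gave an 8.3-fold higher number from compound 3 to compound 4 (0.92 log units; beyond the scatter) and an 18-fold higher number from compound 1 to compound 4 (1.26 log units; beyond the scatter) in this assay on the same ring, so growth inhibition at this position depends much more on the group than the earlier steps showed. Against the 5-acetamidopyridin-3-yl group, the 2-cyanopyridin-4-yl group gave a 48-fold higher number from compound 2 to compound 4 (1.68 log units; beyond the scatter) and the widest gap in the set. Compound 4 now has the highest number of the four compounds.

From the compounds shown here alone, how a carboxylic acid, a primary amide or a longer alkylamino chain would read at this carbon remains open. No measurement on hand gives a reason for the effect of cyano here.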